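The compounds below may be only part of what the source reports. "The series", "measured", "known", "first", "only" and "open" are said of these compounds alone.

The measured compounds:

Compound 1 `N#Cc1ccc(N2CCCc3c(-c4cccnc4)cccc32)cc1C(F)(F)F` gives 10500 nM in an ADME assay on L02 cells (Homo sapiens) for antiproliferative activity, read by CCK-8 assay, with a stated time of 6 days; on this read-out lower numbers stand for stronger inhibition and higher numbers for weaker inhibition.
Compound 2 `Cc1noc(C)c1-c1cccc(Oc2ccc(C#N)c(C(F)(F)F)c2)c1` is recorded as "not determined" (no result reported) in this assay.
Compound 3 `CCN(c1ccc(C#N)c(Cl)c1)c1cc(-c2cccs2)ccc1C` is recorded as "not determined" (no result reported) in this assay.

Among the measured compounds shown here, compound 3 stands without a number of its own, and compound 2 is a further entry without one, so the only number at hand is that of compound 1 in this assay. The step to compound 4 `CCN(c1ccc(C#N)c(Cl)c1)c1cc(-c2ccncc2)ccc1C` is a single exchange: pyridin-4-yl in place of thiophen-2-yl on an aromatic carbon. For the measured compounds named here, no measured pair shows what such an exchange does here. Without a reference, the expectation for this assay is a step no larger than the usual scatter, with weak inhibition remaining likely. Compound 4 is estimated to give about 15000 nM, within a range from 5000 nM to 45000 nM.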

Compound 4, half-maximal inhibitory concentration: 1730 nM
The estimate for compound 4 lay 8.7-fold (0.94 log units) above the measured number; measured number outside the range, below it.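

In this assay compound 3 has no single number to set against compound 4, so no step can be read between them. Going by these compounds, what pyridin-4-yl in place of thiophen-2-yl does here stays open. No supporting evidence bears on this result.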